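The compounds below may be only part of what the source reports. "The series", "measured", "known", "first", "only" and "open" are said of these compounds alone.

Compounds measured:

Compound 1 `COc1ccc(CNC(=O)c2cc(-c3cncc(C)c3)ncc2-c2cnn(C)c2)nc1OC`: 930 nM
Compound 2 `COc1ccc(CNC(=O)c2cc(-c3cncc(C)c3)ccc2-c2ccccc2)nc1OC`: 1000 nM

The study rests on two measured compounds. In an assay on CHO cells for displacement of a labelled ligand from Orexin/Hypocretin receptor type 1 variant I408V (Homo sapiens), read by scintillation counting (on this read-out lower numbers stand for stronger inhibition and higher numbers for weaker inhibition), compound 1 gives 930 nM, and in this assay compound 2 gives 1000 nM. Compound 1 has the lowest of the two numbers, but the value of compound 2 lies within the usual scatter of it, so the two results cannot be told apart. Among the measured compounds shown here, no step between measured compounds that differ in one place is available.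

The unmeasured compound 3 `COc1ccc(CNC(=O)c2cc(-c3cncc(C)c3)ncc2-c2cnccn2)nc1OC` is derived from compound 1 by one change: pyrazin-2-yl in place of 1-methyl-1H-pyrazol-4-yl on an aromatic carbon. Both groups that leave and enter carry the same number of heavy atoms and of hydrogen-bond acceptors, so the change is a like-for-like swap of a five-membered aromatic ring for a six-membered one at the same place on the shared core of compound 1.

For the measured compounds named here, with no measured step of this kind to lean on, compound 3 is expected to stay close to compound 1, with the step of a 1.3-fold higher number from compound 1 to compound 3 (0.11 log units; within the scatter) judged small and not clearly beyond the scatter. Compound 3 is therefore estimated at 1200 nM in this assay, with a likely range from 400 nM to 4000 nM.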

Compound 3, inhibition constant: 31000 nM
The estimate for compound 3 lay 26-fold (1.41 log units) below the measured number, outside the stated range (above it).
By their numbers in this assay, from the lowest: compounds 1 and 2 (each within the scatter of the next); then compound 3.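

In this assay, putting pyrazin-2-yl in place of 1-methyl-1H-pyrazol-4-yl gives a 33-fold higher number from compound 1 to compound 3 (1.52 log units; beyond the scatter), a large step that shows this position, on an aromatic carbon of a six-membered aromatic ring with 1 nitrogen and ortho to a large group, is sensitive to which aromatic ring it carries. The two groups have the same counts of heavy atoms, carbon, nitrogen and hydrogen-bond acceptors, so those counts alone do not secure the value here, and the listed difference between them is a five-membered aromatic ring against a six-membered one. Nothing measured in the study accounts for this loss.

The compounds shown leave open whether the loss follows the size of the ring, the placing of its nitrogen atoms or the absence of the methyl group carried by the leaving group, and a 1H-pyrazol-4-yl, a 1-methyl-1H-imidazol-4-yl or a pyrimidin-5-yl group at this place would separate these readings. They also leave open how an open-chain group, such as an amine or a methoxy group, would fare at this position.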